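Urea Pyrazoles Against a Kidney Carcinoma Line

A few compounds are considered here, and "the series" means these few. Any claim that something is new, unique, unknown or untested is made for them only; others in the source may bear on it.

compound 1 `O=C(Nc1cccc(-n2cc(-c3ccncc3)c(-c3ccc(Cl)c(O)c3)n2)c1)Nc1cccc(C(F)(F)F)c1`: > 32500 nM
compound 2 `O=C(Nc1cccc(-n2cc(-c3ccncc3)c(-c3ccc(Cl)c(O)c3)n2)c1)Nc1ccc(Cl)c(Cl)c1`: > 32500 nM
compound 3 `COc1cc(-c2nn(-c3cccc(NC(=O)Nc4ccc(Cl)c(C(F)(F)F)c4)c3)cc2-c2ccncc2)ccc1Cl`: > 32500 nM

In a functional assay on CAKI-1 cells (Homo sapiens) for inhibition, read by sulforhodamine B assay, with a stated time of 48 h (on this read-out lower numbers stand for higher toxicity in this test and higher numbers for lower toxicity in this test), compound 3 sits at the limit of the assay, with a value that is a limit rather than a number. The same holds for compound 1 and for compound 2, so the step that the two limits leave unreadable from compound 1 to compound 2 cannot be read. The three values share (the limit of > 32500 nM in this assay, at which 3 of the 3 values shown sit). The unmeasured compound 4 `O=C(Nc1cccc(-n2cc(-c3ccncc3)c(-c3ccc(Cl)c(O)c3)n2)c1)Nc1ccc(Cl)c(C(F)(F)F)c1` differs from compound 3 by hydrogen in place of methyl on an oxygen on an aromatic ring. Compound 1 and compound 2 already carry the hydroxy group and also sit at the limit, so no readable step bears on this change. Compound 4 is therefore expected to sit at the limit as well, with an estimated 50000 nM spanning 20000 nM to 200000 nM in this assay, and the expected step is a step that the limit leaves unreadable from compound 3 to compound 4.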

Compound 4, concentration lethal to 50% of the cells: > 32500 nM
Compound 4: no number, only a limit; the forecaster's own chance of this, stated with the estimate: 85%; the middle value lies beyond the limit too.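

Within the data shown here, no step from compound 3, compound 2 or compound 1 to compound 4 can be read, as each value is a limit, not a number: the limit of > 32500 nM in this assay, at which 4 of the 4 values shown sit. The compounds shown leave open how these four compounds truly rank in this assay.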